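The source may hold more compounds than are shown below. What is called first, only, known or untested is meant among the compounds shown, and "the series" means these compounds.

Compound 1 `O=C1/C(=C/c2ccccc2)CCC/C1=C\c1cccc([N+](=O)[O-])c1`: 3000 nM
Compound 2 `O=C1/C(=C/c2ccc(F)cc2)CCC/C1=C\c1cccc([N+](=O)[O-])c1`: 1000 nM
Compound 3 `O=C1/C(=C/c2ccccc2)CCC/C1=C\c1ccc([N+](=O)[O-])cc1`: 20000 nM

Of the compounds shown here, three have been measured in a functional assay on HL-60 cells (Homo sapiens) for cytotoxicity, with a stated time of 24 h; a lower number here means that less compound is tolerated, a higher number that more compound is tolerated. Compound 1 gives 3000 nM, compound 2 gives 1000 nM, and compound 3 gives the highest of the three numbers, 20000 nM. The change fluoro in place of hydrogen on an aromatic carbon made a step of a 3.0-fold lower number from compound 1 to compound 2 (0.48 log units; beyond the scatter). Compound 3 has the same atoms as compound 1 joined differently; the difference between the two cores is not broken down here. Compound 4 `O=C1/C(=C/c2ccc(F)cc2)CCC/C1=C\c1ccc([N+](=O)[O-])cc1` differs from compound 3 by fluoro in place of hydrogen on an aromatic carbon, the same change at a place described in the same words. Because the earlier step was a 3.0-fold lower number from compound 1 to compound 2 (0.48 log units; beyond the scatter), a step of similar size is expected in this assay, namely a 2.9-fold lower number from compound 3 to compound 4 (0.46 log units; beyond the scatter). Compound 4 is therefore estimated at 7000 nM, expected to lie between 2500 nM and 20000 nM.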

Compound 4, half-maximal cytotoxic concentration: 32000 nM
Beside the measured number, compound 4's estimate is 4.6-fold (0.66 log units) below it, outside the stated range (above it).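

In this assay, the change from phenyl to 4-fluorophenyl gave a 1.6-fold higher number from compound 3 to compound 4 (0.20 log units; within the scatter), so the step seen on the core of compound 1 did not carry over to the core of compound 3. Set side by side, the two steps differ: the same change on two cores in this assay, a 3.0-fold lower number (0.48 log units; beyond the scatter) from compound 1 to compound 2 and a 1.6-fold higher number (0.20 log units; within the scatter) from compound 3 to compound 4, 4.8-fold (0.68 log units) apart, beyond the scatter of two such steps This shows that, in this series, the step measured on one core cannot be assumed to hold on the other, but it does not show what sets the two cores apart or how the change would behave on a third core.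

The compounds shown leave open whether chloro or methoxy on the same aromatic carbon would also differ between the two cores. They also leave open whether an amine or a carboxylic acid in place of the nitro group would alter the comparison.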